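Aryl fluorine position within the pyrrolidine-tailed amides

A few compounds are considered here, and "the series" means these few. Any claim that something is new, unique, unknown or untested is made for them only; others in the source may bear on it.

Among the measured compounds shown here, compound 3 `COc1cc2c(Oc3ccc(NC(=O)c4cc(-c5ccc(F)cc5)ccn4)cc3F)ccnc2cc1OCCCN1CCCC1` gives 350 nM in a functional assay on MKN-45 cells (Homo sapiens) for cytotoxicity, read by MTT assay, with a stated time of 72 h (a lower number here means a stronger inhibitor, a higher number a weaker inhibitor), the second highest of the three numbers measured so far. Its nearest neighbour is compound 2 `COc1cc2c(Oc3ccc(NC(=O)c4cc(-c5ccccc5C)ccn4)cc3F)ccnc2cc1OCCCN1CCCC1` at 440 nM, and the step of a 1.3-fold lower number from compound 2 to compound 3 (0.10 log units; within the scatter) is within the scatter. Compound 1 `COc1cc2c(Oc3ccc(NC(=O)c4cc(-c5ccccc5F)ccn4)cc3F)ccnc2cc1OCCCN1CCN(C)CC1` lies furthest away at 150 nM, a separation from compound 3 that is beyond the scatter. Compound 4 `COc1cc2c(Oc3ccc(NC(=O)c4cc(-c5ccccc5F)ccn4)cc3F)ccnc2cc1OCCCN1CCCC1` has not been measured; relative to compound 3 the change is 2-fluorophenyl in place of 4-fluorophenyl on an aromatic carbon. For the measured compounds named here, no measured step moves the fluorine alone. Going by the values given here, the one measured step on this aryl ring, a 1.3-fold lower number from compound 2 to compound 3 (0.10 log units; within the scatter), was small and within the scatter, which argues for little effect from aryl substitution here. Compound 1 carries the same 2-fluorophenyl as compound 4 but a different basic tail, so its number bears on the question only loosely. A modest move to a lower number is expected for compound 4, a 1.4-fold lower number from compound 3 to compound 4 (0.15 log units; within the scatter), not clearly beyond the scatter. The estimate for compound 4 in this assay is 250 nM, in the range 120 nM to 550 nM.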

Compound 4, half-maximal inhibitory concentration: 230 nM
Compound 4: the middle estimate sits 1.1-fold (0.04 log units) above what was measured, and the stated range covers the measured number.
By their numbers in this assay, from the lowest: compounds 1, 4, 3 and 2 (each within the scatter of the next, the first and the last beyond it).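

In this assay, among the compounds shown here, the fluorine now moves alone for the first time, and 2-fluorophenyl in place of 4-fluorophenyl gives a 1.5-fold lower number from compound 3 to compound 4 (0.18 log units; within the scatter) so the position of the fluorine on this aryl ring is not resolved here. Fluoro in place of methyl at the same place gives a 1.9-fold lower number from compound 2 to compound 4 (0.28 log units; within the scatter) and pyrrolidin-1-yl in place of 4-methylpiperazin-1-yl on the 2-fluorophenyl compounds gives a 1.5-fold higher number from compound 1 to compound 4 (0.19 log units; within the scatter) so neither the aryl substituent nor the tail separates these pairs. Nothing on hand offers an explanation for these steps.

Open, from the compounds shown here alone, is whether a chloro or methoxy group on the aryl ring, or a plain phenyl, would give a step beyond the scatter. Equally open is whether a morpholine tail would stand apart from the two tails seen so far in this assay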